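Adding a 2,4-dichlorobenzyl group to compound 2

A few compounds are considered here, and "the series" means these few. Any claim that something is new, unique, unknown or untested is made for them only; others in the source may bear on it.

Measured so far in a functional assay on NCI-H460 cells (Homo sapiens) for cytotoxicity, read by MTT assay, with a stated time of 72 h; a lower number here means a stronger inhibitor, a higher number a weaker inhibitor:
- compound 1 `CN(C)Cc1ccc2nc(NC(=O)N/N=C/c3cn(Cc4ccccc4Cl)c4ccccc34)sc2c1` gives 1600 nM
- compound 2 `CN(C)Cc1ccc2nc(NC(=O)N/N=C/c3c[nH]c4ccccc34)sc2c1` gives 2550 nM

For the measured compounds named here, these are the only two numbers available, and they lie within the usual scatter of repeated measurements, so compound 2 cannot be separated from compound 1. The next molecule, compound 3 `CN(C)Cc1ccc2nc(NC(=O)N/N=C/c3cn(Cc4ccc(Cl)cc4Cl)c4ccccc34)sc2c1`, is built from compound 2 by putting 2,4-dichlorobenzyl in place of hydrogen on an aromatic nitrogen.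

Going by the values given here, one measured step bears on this change. Replacing 2-chlorobenzyl with hydrogen at that nitrogen gave a 1.6-fold higher number from compound 1 to compound 2 (0.20 log units; within the scatter). Among the compounds with values here, compound 3 goes the opposite way, regaining a chlorinated benzyl group, but no measurement yet shows what its extra chlorine does. The small size of that one step suggests no change beyond the scatter in this assay, with at most a slight drift toward a lower number.

The estimated step is a 1.8-fold lower number from compound 2 to compound 3 (0.26 log units; within the scatter).

For compound 3, the expected value is 1400 nM, with an estimated range of 650 nM to 3000 nM.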

Compound 3, half-maximal inhibitory concentration: 950 nM
Compound 3: middle estimate off by 1.5-fold (0.17 log units), on the high side; low and high end bracket the measured number.
By their numbers in this assay, from the lowest: compounds 3, 1 and 2 (each within the scatter of the next, the first and the last beyond it).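

In this assay, for the compounds shown here, putting 2,4-dichlorobenzyl in place of hydrogen on the aromatic nitrogen gives a 2.7-fold lower number from compound 2 to compound 3 (0.43 log units; beyond the scatter), the first change at this nitrogen to stand beyond the scatter, though it remains a modest one. The extra chlorine cannot be credited with that shift on its own: chloro in place of hydrogen on an aromatic carbon gives a 1.7-fold lower number from compound 1 to compound 3 (0.23 log units; within the scatter), so the two chlorinated benzyl compounds cannot be told apart. No measurement at hand offers a reason for the shift seen with 2,4-dichlorobenzyl.

The compounds shown carry only hydrogen or a chlorinated benzyl group on this nitrogen, so it remains open whether an unsubstituted benzyl or a small methyl group would sit with compound 2 or with compound 3. From the compounds shown here alone, it is equally open whether the chlorines themselves matter or whether fluoro or methoxy groups on the same benzyl ring would give similar numbers.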